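Swapping Diethylamino for Piperidinyl on Two Alkoxy Chains

The compounds below may be only part of what the source reports. "The series", "measured", "known", "first", "only" and "open" are said of these compounds alone.

Compound 1, `CCN(CC)CCCCOc1ccc(/C=C/C(=O)Nc2ccccc2)cc1OC`, gives 1.59 in a physicochemical assay for lipophilicity, using the shake flask method, measured as octanol-water partition, at pH 7.4; on this read-out higher numbers stand for higher lipophilicity and lower numbers for lower lipophilicity.
Compound 2, `COc1cc(/C=C/C(=O)Nc2ccccc2)ccc1OCCCCN1CCCCC1`, gives 1.61 in this assay.
Compound 3, `CCOC(=O)/C=C/c1ccc(OCCCCCCN(CC)CC)c(OC)c1`, gives 1.8 in this assay.

The change from compound 1 to compound 2 is piperidin-1-yl in place of diethylamino on a saturated chain carbon, four bonds along the chain from an oxygen on an aromatic ring. It produced a number 0.02 log units higher from compound 1 to compound 2 (within the scatter). Compound 4, `CCOC(=O)/C=C/c1ccc(OCCCCCCN2CCCCC2)c(OC)c1`, arises from compound 3 by the same kind of change, (piperidin-1-yl in place of diethylamino on a saturated chain carbon, six bonds along the chain from an oxygen on an aromatic ring); the place differs in that the group sits six bonds along the chain from an oxygen on an aromatic ring rather than four. The difference between the core of compound 1 and the core of compound 3 is not broken down here. Because a number 0.02 log units higher from compound 1 to compound 2 (within the scatter) stayed within the scatter, compound 4 is expected to show a step of a number 0.02 log units higher from compound 3 to compound 4 (within the scatter), matching the earlier one. Compound 4 is therefore estimated at 1.82, between 1.52 and 2.12.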

Compound 4, partition coefficient: 1.81
The estimate for compound 4 lay 0.01 log units above the measured number, within the range that was stated.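

The new step is a number 0.01 log units higher from compound 3 to compound 4 (within the scatter), and the earlier one on the other core is a number 0.02 log units higher from compound 1 to compound 2 (within the scatter), so in this assay piperidin-1-yl in place of diethylamino gave a step within the scatter on both the core of compound 1 and the core of compound 3. Two pairs cannot show that this holds on every core, and since the cores and the distance along the chain both differ, they do not separate one from the other. Nothing shown here gives a reason for this result.

The compounds shown leave open whether morpholin-4-yl or pyrrolidin-1-yl in the same place would give a similar number. Also open, going by these compounds, is how the swap behaves on a longer chain or on a core carrying a carboxylic acid.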